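The source may hold more compounds than are shown below. What is called first, only, known or untested is meant among the compounds shown, and "the series" means these compounds.

Measured so far in an assay on CHO cells for displacement of a labelled ligand from adenosine receptor A3 (Homo sapiens), with a stated time of 60 min; on this read-out lower numbers stand for stronger inhibition and higher numbers for weaker inhibition:

Compound 1, `O[C@@H]1[C@H](O)[C@@H]2C[C@@H]2[C@H]1n1cnc2c(NCCCF)nc(Cl)nc21`, gives 32.4 nM.
Compound 2, `CCC(CC)Nc1nc(Cl)nc2c1ncn2[C@H]1[C@H](O)[C@H](O)[C@@H]2C[C@@H]21`, gives 52 nM.
Compound 3, `O[C@@H]1[C@H](O)[C@@H]2C[C@@H]2[C@H]1n1cnc2c(NCc3ccccc3F)nc(Cl)nc21`, gives 41.5 nM.

Compound 3 stands second highest of these three numbers, but every gap among them is within the scatter: a 1.3-fold higher number from compound 1 to compound 3 (0.11 log units; within the scatter), a 1.3-fold lower number from compound 2 to compound 3 (0.10 log units; within the scatter) and a 1.6-fold higher number from compound 1 to compound 2 (0.21 log units; within the scatter). So far, then, swapping the group on the ring nitrogen of the shared core, whether a short chain, a branched chain or a 2-fluorobenzyl group, has not moved this assay by a clear amount.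

Compound 4, `O[C@@H]1[C@H](O)[C@@H]2C[C@@H]2[C@H]1n1cnc2c(NCc3ccccc3OCCF)nc(Cl)nc21`, carries the change (2-fluoroethoxy in place of fluoro on an aromatic carbon). Within the data shown here, no measured step touches this exact replacement; the steps that come nearest, from compound 1 to compound 3 and from compound 2 to compound 3, both stay within the scatter. Since even larger reshaping of this part of the molecule left the number unchanged within the scatter, the expectation for compound 4 is no step beyond the scatter, a 1.2-fold higher number from compound 3 to compound 4 (0.08 log units; within the scatter). The estimate for compound 4 in this assay is therefore 50 nM, with a range from 15 nM to 170 nM.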

Compound 4, inhibition constant: 10.3 nM
Compound 4: the middle estimate sits 4.9-fold (0.69 log units) above what was measured; measured number below the stated range.
By their numbers in this assay, from the lowest: compound 4; then compounds 1, 3 and 2 (each within the scatter of the next).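

In this assay, among these compounds, putting 2-fluoroethoxy in place of fluoro on the aromatic carbon ortho to a large group gives a 4.0-fold lower number from compound 3 to compound 4 (0.61 log units; beyond the scatter), a step beyond the scatter, whereas every gap among the earlier compounds stayed within it. The change from a 2-fluoroethyl group to a 2-(2-fluoroethoxy)phenyl group gives a 3.1-fold lower number from compound 1 to compound 4 (0.50 log units; beyond the scatter), so the larger group on the chain carbon also separates clearly from the short fluorinated chain. Nothing available here explains why this change lowers the number.

A single replacement cannot show whether the lower number goes with the added oxygen, the added carbons or the fluorine at the end of the chain, and a plain ethoxy or methoxy group would separate these parts. Going by these compounds, whether the trend continues with a longer chain such as 3-fluoropropoxy, or holds for an amine on the same aromatic carbon, also remains open.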